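A few compounds are considered here, and "the series" means these few. Any claim that something is new, unique, unknown or untested is made for them only; others in the source may bear on it.

Compound 1 `C/C(=N\NC(=O)COc1cccc2ccccc12)c1ccc(C#N)cc1Br` has been tested in an ADME assay on HEL cells (Homo sapiens) for cytotoxicity (a lower number here means that less compound is tolerated, a higher number that more compound is tolerated), where compound 1 gives 20 ug/mL, the lowest of the three numbers. Compound 2 `O=C(COc1cccc2ccccc12)N/N=C/c1ccc(Cl)cc1` gives 100 ug/mL, and compound 3 `O=C(COc1cccc2ccccc12)N/N=C/c1cccc(O)c1` gives 100 ug/mL, each beyond the scatter from compound 1. Among the measured compounds shown here, the only measured step, no change at the digits printed from compound 2 to compound 3 (within the scatter), shows that swapping the aryl ring left the read-out unchanged, though compounds 2 and 3 differ from compound 1 in more than that ring. Compound 4 `C/C(=N\NC(=O)COc1cccc2ccccc12)c1ccccc1O` differs from compound 1 by 2-hydroxyphenyl in place of 2-bromo-4-cyanophenyl on a carbon with a double bond to nitrogen. The entering ring carries a hydroxyl, as does the ring of compound 3, whose value is 100 ug/mL. Compound 4 is therefore expected to show an upward step, a 2.5-fold higher number from compound 1 to compound 4 (0.40 log units; beyond the scatter). Compound 4 is estimated at 50 ug/mL, with a range from 20 ug/mL to 100 ug/mL.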

Compound 4, minimum cytotoxic concentration: 20 ug/mL
Compound 4: the middle estimate sits 2.5-fold (0.40 log units) above what was measured; low and high end bracket the measured number.
By their numbers in this assay, from the lowest: compounds 1 and 4 (each within the scatter of the next); then compounds 2 and 3 (each within the scatter of the next).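

In this assay replacing the ring on this carbon gives no change at the digits printed from compound 1 to compound 4 (within the scatter) and so the 2-bromo-4-cyanophenyl group can leave this place, with 2-hydroxyphenyl entering, without any measurable shift in the read-out. The earlier compounds shown here could not show this, since none shared the saturated chain carbon of compound 1 and differed from it only in this ring. No available evidence accounts for this result.

On these data alone, it remains open whether an amine or a carboxylic acid on this ring would leave the number equally unmoved. Also open, as far as these compounds go, is whether a longer chain in place of the saturated chain carbon would alter it.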